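Adding a fluoro to a pyrrolopyrimidine ether amide

The compounds below may be only part of what the source reports. "The series", "measured", "known", "first", "only" and "open" are said of these compounds alone.

Compound 1 `Cc1cc(=O)n(-c2ccccc2OC(F)(F)F)nc1C(=O)Nc1ccc(Oc2ncnc3[nH]ccc23)c(F)c1`: > 60000 nM
Compound 2 `Cc1cc(=O)n(-c2ccccc2OC(F)(F)F)nc1C(=O)Nc1ccc(Oc2ncnc3c2ccn3C)cc1`: 5160 nM

In a functional assay on PC-3 cells (Homo sapiens) for cytotoxicity, read by MTT assay, with a stated time of 72 h (a lower number here means a stronger inhibitor, a higher number a weaker inhibitor), compound 1 reaches only the limit of the assay, > 60000 nM, not a number. Within the data shown here, compound 2 is the only compound with a measured number, 5160 nM in this assay. Compound 3 `Cc1cc(=O)n(-c2ccccc2OC(F)(F)F)nc1C(=O)Nc1ccc(Oc2ncnc3c2ccn3C)c(F)c1` differs from compound 2 by fluoro in place of hydrogen on an aromatic carbon, ortho to a large group and meta to a large group. Among the measured compounds shown here, no measured pair shows this change on its own, so compound 3 is expected to stay near compound 2, within the scatter, as a step of a 1.0-fold lower number from compound 2 to compound 3 (0.01 log units; within the scatter). Compound 3 is therefore estimated at 5000 nM, between 1500 nM and 16000 nM.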

Compound 3, half-maximal inhibitory concentration: > 60000 nM
Compound 3 gave a limit, no number; the forecaster's own chance of this, stated with the estimate: 10%; middle value at least 12-fold (1.07 log units) away from the limit.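

In this assay a single fluoro in place of hydrogen on an aromatic carbon, ortho to a large group and meta to a large group, gives an at least 11-fold higher number from compound 2 to compound 3 (1.06 log units; beyond the scatter) and so weakens the compound clearly at this position. As far as these compounds go, the true size of that step stays unknown, with compound 3 giving only a limit of the assay: the limit of > 60000 nM in this assay, at which 2 of the 3 values shown sit. Compound 1 and compound 3 both stand at limits, so the step between them cannot be read.

From the compounds shown here alone, whether this weakening is particular to fluoro remains open. A chloro, methyl or methoxy group on the same carbon would test that.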